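The compounds below may be only part of what the source reports. "The series", "measured", "known", "first", "only" and "open" are said of these compounds alone.

Measured in a functional assay on HT-29 cells (Homo sapiens) for cytotoxicity, read by MTT assay, with a stated time of 48 h; on this read-out higher numbers stand for weaker inhibition and lower numbers for stronger inhibition:
Compound 1 `C=C1C(=O)Oc2cc(OC)ccc2C1C`: 70000 nM
Compound 2 `C=C1C(=O)Oc2cc(OC)ccc2C1CCCC`: 10200 nM

Compound 2 has the lower of the two numbers. Compound 3 `C=CC1C(=C)C(=O)Oc2cc(OC)ccc21` differs from it by vinyl in place of butyl on a saturated ring carbon, with vinyl in place of butyl on a saturated ring carbon. Within the data shown here, the only measured step that bears on this is a 6.9-fold lower number from compound 1 to compound 2 (0.84 log units; beyond the scatter), a modest one. Among the measured compounds shown here, no vinyl compound has been measured, so compound 3 is expected to give back part of that step, with a modest rise in the number in this assay. The expected size is a 2.2-fold higher number from compound 2 to compound 3 (0.33 log units; beyond the scatter). For compound 3 the estimated value is 22000 nM, with a range of 8000 nM to 60000 nM.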

Compound 3, half-maximal inhibitory concentration: 42000 nM
For compound 3 the middle estimate is 1.9-fold (0.28 log units) below the measured one; the range from low to high includes it.
By their numbers in this assay, from the lowest: compound 2; then compounds 3 and 1 (each within the scatter of the next).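

In this assay, vinyl in place of butyl on the saturated ring carbon gives a 4.1-fold higher number from compound 2 to compound 3 (0.61 log units; beyond the scatter), so the vinyl group does not keep the gain seen with butyl. Vinyl in place of methyl gives a 1.7-fold lower number from compound 1 to compound 3 (0.22 log units; within the scatter), which leaves these two groups not told apart at this position, with only butyl standing apart among the three. No evidence bearing on the reason accompanies these numbers. The compounds shown leave open whether an ethyl group would match vinyl here, and whether a chain longer than butyl or an amine on this carbon would give a lower number than compound 2.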